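The source may report more compounds than this note shows. Statements on the series, on what has been measured and on what is new or still open speak of the compounds shown alone.

Measured so far:
compound 1 `Cc1cn([C@@H]2O[C@H](COP(=O)(O)O)[C@@H](CN)[C@H]2O)c(=O)[nH]c1=O` — 280000 nM
compound 2 `Cc1cn([C@H]2C[C@H](CN)[C@@H](COP(=O)(O)O)O2)c(=O)[nH]c1=O` — 4700 nM

In an assay on isolated protein for inhibition of thymidine kinase, cytosolic (Homo sapiens) (on this read-out higher numbers stand for weaker inhibition and lower numbers for stronger inhibition), compound 2 gives the lowest of the two numbers seen, so it is the stronger inhibitor of the pair; compound 1 sits a long way above it, as the step of a 60-fold lower number from compound 1 to compound 2 (1.78 log units; beyond the scatter) shows, which is well beyond the scatter. Compound 3 `Cc1cn([C@H]2C[C@H](CO)[C@@H](COP(=O)(O)O)O2)c(=O)[nH]c1=O` differs from compound 2 in one place: hydroxy in place of amino on a saturated chain carbon bound to a saturated ring carbon. Going by the values given here, no measured step covers this exchange. Among the compounds with values here, the only step known, a 60-fold lower number from compound 1 to compound 2 (1.78 log units; beyond the scatter), concerns the loss of a hydroxy on a saturated ring carbon, a different change at a different place, so it offers no direct guide here. With nothing to lean on, a modest change in this assay is expected for compound 3, most likely toward a somewhat higher number, a 1.9-fold higher number from compound 2 to compound 3 (0.28 log units; within the scatter). The estimate for compound 3 is therefore 9000 nM, within a range from 2000 nM to 40000 nM.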

Compound 3, inhibition constant: 43500 nM
The estimate for compound 3 lay 4.8-fold (0.68 log units) below the measured number; the measured number lies above the stated range.
By their numbers in this assay, from the lowest: compound 2; then compound 3; then compound 1.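

In this assay, the exchange of amino for hydroxy on a saturated chain carbon bound to a saturated ring carbon gives a 9.3-fold higher number from compound 2 to compound 3 (0.97 log units; beyond the scatter) and so lies beyond the scatter. This position therefore responds to which of the two groups it carries, even though amino and hydroxy match in their counts of heavy atoms, hydrogen-bond donors and acceptors, and neither carries a net charge. Of this pair, aminomethyl goes with the stronger inhibition and hydroxymethyl with the weaker, and no measurement available here accounts for that difference.

As far as these compounds go, it remains open whether a methylamino group, a longer aminoethyl chain or a carboxylic acid at this place would give a lower or a higher number. From the compounds shown here alone, it is also open whether the same exchange would matter as much on the core of compound 1, which keeps its ring hydroxy.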